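This account rests on a few compounds, and the source may have more. Where it says the series, first, only, none or still open, it means among the compounds named here.

Compound 2 `CN1CCN(CCCCOc2c(OCc3cccs3)cc(O)c3c(=O)cc(-c4ccccc4)oc23)CC1` has the lowest of the two numbers measured in a functional assay on B16 cells (Mus musculus) for cytotoxicity, read by MTT assay, with a stated time of 72 h (a lower number here means a stronger inhibitor, a higher number a weaker inhibitor), where compound 2 gives 2120 nM. Compound 1 `Cc1ccc(COc2cc(O)c3c(=O)cc(-c4ccccc4)oc3c2OCCCCN2CCN(C)CC2)cc1` gives 3290 nM in this assay, and the step of a 1.6-fold lower number from compound 1 to compound 2 (0.19 log units; within the scatter) lies within the scatter, so the two compounds cannot be told apart. Compound 3 `CN1CCN(CCCCOc2c(OCc3nc4ccccc4o3)cc(O)c3c(=O)cc(-c4ccccc4)oc23)CC1` differs from compound 2 by 1,3-benzoxazol-2-yl in place of thiophen-2-yl on a saturated chain carbon bound to an oxygen on an aromatic ring. Among the compounds with values here, the only measured step that bears on this change is the one from compound 1 to compound 2, which also exchanged one aromatic group for another at the same place and moved the number by less than the usual scatter. A further exchange of the aromatic group at that place is therefore expected to move the number little, with no clear direction, and the expected step from compound 2 to compound 3 is a 1.0-fold higher number from compound 2 to compound 3 (0.02 log units; within the scatter). Compound 3 is estimated to give 2200 nM in this assay, within a range from 700 nM to 7000 nM.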

Compound 3, half-maximal inhibitory concentration: 2080 nM
Estimate against measurement, compound 3: 1.1-fold (0.02 log units) above, and the stated range covers the measured number.
By their numbers in this assay, from the lowest: compounds 3, 2 and 1 (each within the scatter of the next).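

Replacing thiophen-2-yl with 1,3-benzoxazol-2-yl adds a six-membered aromatic ring and raises the group from 5 to 9 heavy atoms, yet this assay gives a 1.0-fold lower number from compound 2 to compound 3 (0.01 log units; within the scatter) and so shows no measurable change. The exchange of 4-methylphenyl for the same group gives a 1.6-fold lower number from compound 1 to compound 3 (0.20 log units; within the scatter) and also stays within the scatter. This place on a saturated chain carbon bound to an oxygen on an aromatic ring has now taken three different aromatic groups, including a larger one with two rings, with no difference that can be read, and no measurement here accounts for this.

From the compounds shown here alone, all three groups are aromatic, so the effect of a cyclohexyl ring, an amine or a carboxylic acid at this place remains open. A longer chain carrying the aromatic group also remains untested in the compounds shown.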